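A few compounds are considered here, and "the series" means these few. Any claim that something is new, unique, unknown or untested is made for them only; others in the source may bear on it.

Of the compounds shown here, three built on one shared core have been measured so far. Compound 1 `COC(=O)[C@@]1(C)CCC=C2[C@@H]1CC[C@@H](C)[C@]2(C)Cc1c[nH]c2ccc(C)cc12` gives 17000 nM in a functional assay on A549 cells (Homo sapiens) for inhibition, read by sulforhodamine B assay, with a stated time of 48 h; a higher number here means a weaker inhibitor of growth, a lower number a stronger inhibitor of growth. Compound 2 `COC(=O)[C@@]1(C)CCC=C2[C@@H]1CC[C@@H](C)[C@]2(C)Cc1c[nH]c2ccc(Br)cc12` gives 15000 nM in this assay, and compound 3 `COC(=O)[C@@]1(C)CCC=C2[C@@H]1CC[C@@H](C)[C@]2(C)Cc1c[nH]c2ccc(Cl)cc12` gives 16000 nM in this assay. Compound 3 therefore sits with the other two: the change a 1.1-fold lower number from compound 1 to compound 3 (0.03 log units; within the scatter) and the change a 1.1-fold higher number from compound 2 to compound 3 (0.03 log units; within the scatter) both stay inside the scatter, and the same holds for a 1.1-fold lower number from compound 1 to compound 2 (0.05 log units; within the scatter). Nothing among these three separates one substituent from another on that aromatic carbon.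

Compound 4 `COC(=O)[C@@]1(C)CCC=C2[C@@H]1CC[C@@H](C)[C@]2(C)Cc1c[nH]c2ccc(F)cc12` continues the series with a further exchange at the same place: fluoro in place of chloro on an aromatic carbon. Within the data shown here, the steps that bear on it are the two earlier exchanges at this carbon, a 1.1-fold lower number from compound 1 to compound 3 (0.03 log units; within the scatter) and a 1.1-fold higher number from compound 2 to compound 3 (0.03 log units; within the scatter), neither of which moved the number beyond the scatter. On that basis no step beyond the scatter is expected in this assay for compound 4, in either direction. The estimate for compound 4 is 16000 nM, within a range from 8000 nM to 32000 nM, which means an expected step of no change at the digits printed from compound 3 to compound 4 (within the scatter).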

Compound 4, concentration for 50% growth inhibition: 6200 nM
Estimate against measurement, compound 4: 2.6-fold (0.41 log units) above; measured number outside the range, below it.
By their numbers in this assay, from the lowest: compound 4; then compounds 2, 3 and 1 (each within the scatter of the next).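

Among these compounds, at this aromatic carbon the substituent does make a difference in this assay, which the earlier compounds did not show: fluoro separates from all three other groups, with a 2.6-fold lower number from compound 3 to compound 4 (0.41 log units; beyond the scatter) for fluoro in place of chloro, a 2.4-fold lower number from compound 2 to compound 4 (0.38 log units; beyond the scatter) for fluoro in place of bromo and a 2.7-fold lower number from compound 1 to compound 4 (0.44 log units; beyond the scatter) for fluoro in place of methyl. Methyl, bromo and chloro remain within the scatter of one another, so compound 4 stands alone, though each of its steps is only modest. Nothing available here explains why fluoro alone stands apart.

The compounds shown leave open whether a plain hydrogen, a methoxy group or a nitrile at this carbon would fall with fluoro or with the other three. As far as these compounds go, only this one carbon varies among them, so the effect of a change elsewhere on the shared core, such as a carboxylic acid in place of the methyl ester, also remains open.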